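A few compounds are considered here, and "the series" means these few. Any claim that something is new, unique, unknown or untested is made for them only; others in the source may bear on it.

Of the compounds shown here, two built on a shared core have been tested in an ADME assay on cells (Rhabdomyosarcoma cell, Homo sapiens) for cytotoxicity, read by MTT assay, with a stated time of 72 h; on this read-out higher numbers stand for lower toxicity in this test and lower numbers for higher toxicity in this test. Compound 1 `C(=C/c1ccccc1)\C=N\c1sc2c(c1-c1nc3ccccc3s1)CCC2` gives 122 ug/mL in this assay. Compound 2 `Clc1ccc(/C=N/c2sc3c(c2-c2nc4ccccc4s2)CCCC3)cc1` carries a 4-chlorophenyl group on a carbon with a double bond to nitrogen, and its core is not the same as that of compound 1; in this assay compound 2 gives 367 ug/mL. Of the two numbers, compound 2 has the higher one, and the gap to compound 1 lies beyond the usual scatter of repeated measurements.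

Compound 3 `Oc1ccccc1/C=N/c1sc2c(c1-c1nc3ccccc3s1)CCCC2` keeps the core of compound 2 and differs from it in one place: 2-hydroxyphenyl in place of 4-chlorophenyl on a carbon with a double bond to nitrogen. Going by the values given here, no measured pair in this set isolates this change, and the two measured compounds differ in more than this group, so they give no direct guide to what it does. The step expected in this assay a 1.2-fold lower number from compound 2 to compound 3 (0.09 log units; within the scatter) is small, with no clear direction and not beyond the scatter. Compound 3 is therefore expected to give about 300 ug/mL in this assay, within a range from 130 ug/mL to 650 ug/mL.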

Compound 3, half-maximal cytotoxic concentration: 42.4 ug/mL
Compound 3: the middle estimate sits 7.1-fold (0.85 log units) above what was measured; the whole stated range lies above it.
By their numbers in this assay, from the lowest: compound 3; then compound 1; then compound 2.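

The place on a carbon with a double bond to nitrogen is not indifferent in this assay: 2-hydroxyphenyl in place of 4-chlorophenyl gives an 8.7-fold lower number from compound 2 to compound 3 (0.94 log units; beyond the scatter), so on the core of compound 2 this swap goes with clearly higher toxicity in this test. The two groups have the same count of heavy atoms and each holds one six-membered aromatic ring of carbon only, yet the change in the group at this place is enough to move the number well beyond the scatter; what the count shows as different is that the chlorine leaves while a hydrogen-bond donor and a hydrogen-bond acceptor enter. No measurement in hand bears on why the number falls, so the step stands as an observation on this single pair.

This one pair cannot tell whether the entering hydroxyl or the departing chlorine accounts for the step, or whether the same swap would do the same on the core of compound 1. As far as these compounds go, how a plain phenyl, an aminophenyl or a phenyl bearing a carboxylic acid would behave at this place also remains open.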